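The source may hold more compounds than are shown below. What is called first, only, known or untested is meant among the compounds shown, and "the series" means these compounds.

Compound 1 `O=C(/C=C/c1ccc(CN2C(=O)/C(=C3\Nc4ccccc4\C3=N/O)c3cc(Br)ccc32)cc1)NO` gives 60 nM in a functional assay on SW-620 cells (Homo sapiens) for cytotoxicity, read by colorimetric assay; on this read-out lower numbers stand for stronger inhibition and higher numbers for weaker inhibition. Among the three compounds measured so far it stands second highest. Compound 2 `O=C(NO)c1ccc(CN2C(=O)/C(=C3\Nc4ccccc4\C3=N/O)c3cc(Br)ccc32)cc1` gives 70 nM, and the step of a 1.2-fold higher number from compound 1 to compound 2 (0.07 log units; within the scatter) lies within the scatter, so the two numbers cannot be ordered. Compound 3 `Cc1ccc2c(c1)/C(=C1/Nc3ccccc3/C1=N\O)C(=O)N2Cc1ccc(C(=O)NO)cc1` gives 30 nM; its gap to compound 1 is also within the scatter. Between compound 2 and compound 3 the step is a 2.3-fold lower number from compound 2 to compound 3 (0.37 log units; beyond the scatter), a modest shift beyond the scatter.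

Compound 4 `O=C(/C=C/c1ccc(CN2C(=O)/C(=C3\Nc4ccccc4\C3=N/O)c3ccccc32)cc1)NO` differs from compound 1 by hydrogen in place of bromo on an aromatic carbon. Among the measured compounds shown here, the only measured step that touches this position is the one from compound 2 to compound 3, methyl in place of bromo, and it moved the number modestly lower. For the measured compounds named here, no measured compound carries hydrogen at this position, so the effect of simply removing the bromo is not covered by the data. The step from compound 1 to compound 2 concerns the other end of the molecule and is within the scatter. Given one modest step at this position and no direct precedent, the step of a 1.4-fold higher number from compound 1 to compound 4 (0.15 log units; within the scatter) is expected to be small, with the direction uncertain and a slightly higher number somewhat more likely. Compound 4 is therefore estimated at 85 nM, in the range 35 nM to 200 nM.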

Compound 4, half-maximal inhibitory concentration: 50 nM
Beside the measured number, compound 4's estimate is 1.7-fold (0.23 log units) above it; low and high end bracket the measured number.
By their numbers in this assay, from the lowest: compounds 3, 4, 1 and 2 (each within the scatter of the next, the first and the last beyond it).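

Hydrogen in place of bromo on this aromatic carbon gives a 1.2-fold lower number from compound 1 to compound 4 (0.08 log units; within the scatter) in this assay, the first reading at this position without a substituent, and it shows that the bromo can be removed from the 2-(hydroxycarbamoyl)ethenyl series without a change that stands out from the scatter. Among the compounds shown here, until now the position had been read only as a swap of one substituent for another on the hydroxycarbamoyl background, where methyl in place of bromo gave a 2.3-fold lower number from compound 2 to compound 3 (0.37 log units; beyond the scatter), the one step at this position beyond the scatter. No measurement on hand bears on why the bromo can go without a readable effect on the number in this cytotoxicity read-out.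

Still open, from the compounds shown here alone, is whether hydrogen in place of bromo reads the same on the hydroxycarbamoyl background, and whether methyl in place of bromo repeats its modest step on the 2-(hydroxycarbamoyl)ethenyl background. Also open is how far this aromatic carbon tolerates a group of a different kind, such as an amine, a carboxylic acid or a longer alkyl chain, since only bromo, methyl and hydrogen appear there in the compounds shown.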